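The source may report more compounds than this note shows. Statements on the series, on what has been measured and on what is new or still open speak of the compounds shown alone.

Measured compounds:
Compound 1, `O=C(Nc1ccccc1)c1ccc(-c2nn[nH]n2)cc1`, 8.4 mg/kg
Compound 2, `O=C(O)c1ccc(NC(=O)c2ccc(C(=O)O)cc2)cc1`, 25.4 mg/kg
Compound 3, `NC(=O)c1ccc(NC(=O)c2ccc(-c3nn[nH]n3)cc2)cc1`, 2 mg/kg

In a functional assay on the whole organism with Rattus norvegicus as the target, at a dose of 25 mg/kg by the intravenous route (a lower number here means that less compound is needed, a higher number that more compound is needed for the effect), compound 3 gives the lowest number of the three measured compounds; compound 1 gives a higher number, and compound 2 a still higher one. Among the compounds with values here, the one single-point step recorded, a 4.2-fold lower number from compound 1 to compound 3 (0.62 log units; beyond the scatter), shows the carbamoyl entering at the outer ring bringing the number down. Compound 4, `O=C(O)c1ccc(NC(=O)c2ccc(-c3nn[nH]n3)cc2)cc1`, has not yet been measured. It differs from compound 3 by hydroxy in place of amino on a carbonyl carbon. Within the data shown here, no measured pair shows this very change. Compound 2, which carries a carboxy group at both ends, stands well above compound 3, but it differs from compound 4 in more than one place, so its value only hints that a carboxy end does not help. The writer therefore expects compound 4 to sit at or somewhat above compound 3, with a 2.0-fold higher number from compound 3 to compound 4 (0.30 log units; within the scatter) as the expected step. The estimate for compound 4 is 4 mg/kg, with a range from 1.5 mg/kg to 12 mg/kg.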

Compound 4, dose for 50% inhibition: 2.3 mg/kg
Estimate against measurement, compound 4: 1.7-fold (0.24 log units) above, within the range that was stated.
By their numbers in this assay, from the lowest: compounds 3 and 4 (each within the scatter of the next); then compound 1; then compound 2.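

In this assay the change from carbamoyl to carboxy on this carbonyl carbon gives a 1.2-fold higher number from compound 3 to compound 4 (0.06 log units; within the scatter) and so the two groups cannot be told apart here. The tetrazole end now has a direct reading, since 2H-tetrazol-5-yl in place of carboxy on an aromatic carbon gives an 11-fold lower number from compound 2 to compound 4 (1.04 log units; beyond the scatter) and a carboxy group at that end therefore carries a large cost that the same group at the other end does not. Carboxy in place of hydrogen gives a 3.7-fold lower number from compound 1 to compound 4 (0.56 log units; beyond the scatter) and this agrees with a 4.2-fold lower number from compound 1 to compound 3 (0.62 log units; beyond the scatter) in showing that a group at this end lowers the number, whichever of the two it is.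

Going by these compounds, whether a methyl ester or an N-methyl amide at this carbonyl carbon would hold the number stays open. Nothing at hand explains these numbers.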